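A few compounds are considered here, and "the series" means these few. Any claim that something is new, unique, unknown or untested is made for them only; others in the source may bear on it.

Measured compounds in hand:
- compound 1, `NC(=O)c1c(NC(=O)c2ccc(C(F)(F)F)cc2)sc2c1CCN(Cc1ccc(Cl)cc1Cl)C2`, 10900 nM
- compound 2, `Cc1ccccc1C(=O)Nc1sc2c(c1C(N)=O)CCN(C(=S)Nc1ccccc1Cl)C2`, 11000 nM

In a functional assay on MKN-74 cells (Homo sapiens) for antiproliferative activity, with a stated time of 24 h (a higher number here means a weaker inhibitor, a lower number a stronger inhibitor), compound 1 gives 10900 nM. Compound 2 gives 11000 nM. Compound 2 holds the higher of the two numbers, but its gap to compound 1 lies within the scatter, so the two values show no order between them.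

Compound 3, `NC(=O)c1c(NC(=O)c2ccc(C(F)(F)F)cc2)sc2c1CCN(C(=S)Nc1ccccc1Cl)C2`, differs from compound 2 in one place: 4-(trifluoromethyl)phenyl in place of 2-methylphenyl on a carbonyl carbon. Within the data shown here, no measured pair isolates this change, so its size has to be judged from the two values shown. Compound 1 already carries a 4-(trifluoromethyl)phenyl amide and gives 10900 nM, which sits level with compound 2. On that basis the step from compound 2 to compound 3 is expected to be a 1.0-fold lower number from compound 2 to compound 3 (0.02 log units; within the scatter), nothing beyond the scatter in either direction. Compound 3 is therefore estimated at 10500 nM, with a range of 4000 nM to 28000 nM.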

Compound 3, half-maximal inhibitory concentration: 16400 nM
For compound 3 the middle estimate is 1.6-fold (0.19 log units) below the measured one; the range from low to high includes it.
By their numbers in this assay, from the lowest: compounds 1, 2 and 3 (each within the scatter of the next).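

With this assay as the read-out, 4-(trifluoromethyl)phenyl in place of 2-methylphenyl on a carbonyl carbon gives a 1.5-fold higher number from compound 2 to compound 3 (0.17 log units; within the scatter), so this amide position shows no response to this change. With 4-(trifluoromethyl)phenyl held fixed, exchanging the groups on the amine nitrogen in a ring gives a 1.5-fold higher number from compound 1 to compound 3 (0.18 log units; within the scatter), so the two single-place changes now in hand both stay within the scatter and all three compounds sit level. No measurement on hand offers an explanation for this flat result.

As far as these compounds go, whether a carboxylic acid or an amine on the group at the carbonyl carbon would move the number beyond the scatter remains open. The same question stands for a longer alkyl chain on the amine nitrogen in a ring.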